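One Ring Swap on Compound 2

The source may hold more compounds than are shown below. What is called first, only, known or untested is meant among the compounds shown, and "the series" means these compounds.

In an ADME assay on Huh-7 cells (Homo sapiens) for cytotoxicity, read by MTT assay, with a stated time of 4 h, at 37 degrees C (a lower number here means that less compound is tolerated, a higher number that more compound is tolerated), the measured compounds give these values
compound 1 `Cn1c(=O)c(-c2c(Br)cccc2Br)cc2c(N)nc(Nc3ccccc3)nc21` gives 800 nM
compound 2 `O=C1Nc2nc(Nc3ccccc3)nc(On3nnc4ccccc43)c2CC1c1ccc(F)cc1` gives 12200 nM
compound 3 `COc1ccc(Nc2nc3[nH]c(=O)c(-c4ccc(F)cc4)cc3c(=O)[nH]2)cc1` gives 46000 nM

Compound 2 holds the middle place of the three numbers. Its value lies beyond the scatter from both others, below that of compound 3 and above that of compound 1. Compound 4 `O=C1Nc2nc(Nc3ccccc3)nc(On3nnc4ccccc43)c2CC1c1ccc(Cl)cc1Cl` has 2,4-dichlorophenyl in place of 4-fluorophenyl on a saturated ring carbon. Going by the values given here, no two measured compounds differ in just one place, so the data give no direct guide to this change. In this assay a small move to a lower number is expected, possibly none beyond the scatter. The estimated change is a 1.4-fold lower number from compound 2 to compound 4 (0.13 log units; within the scatter) in size. For compound 4 the estimate is 9000 nM with an expected range from 3000 nM to 27000 nM here.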

Compound 4, half-maximal cytotoxic concentration: 5500 nM
Compound 4: the middle estimate sits 1.6-fold (0.21 log units) above what was measured; the range from low to high includes it.
By their numbers in this assay, from the lowest: compound 1; then compound 4; then compound 2; then compound 3.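

Going by these compounds alone, this is the first comparison in the set that changes only one place: on a saturated ring carbon, two ring bonds from the ring nitrogen, this assay shows a 2.2-fold lower number from compound 2 to compound 4 (0.35 log units; beyond the scatter) when 2,4-dichlorophenyl replaces 4-fluorophenyl. The position therefore responds to its aryl group, though only modestly. Nothing available explains this shift.

One swap cannot separate the contributions of the two chlorines, so 4-chlorophenyl remains an open comparison. Also open, on these data alone, is how a phenyl ring carrying an amine or a carboxylic acid would read here.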